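Swapping a Chloro Group for a Cyano Group

The source may report more compounds than this note shows. Statements on the series, on what has been measured and on what is new or still open speak of the compounds shown alone.

Of the compounds shown here, two with a shared core have been measured so far. In a functional assay on Jurkat cells (Homo sapiens) for cytotoxicity, read by luminescence and CellTiter-Glo, with a stated time of 3 days (on this read-out higher numbers stand for weaker inhibition and lower numbers for stronger inhibition), compound 1 `N#Cc1ccc(NC(=O)c2ccc3cccnc3c2O)c(F)c1` gives 420 nM, and compound 2 `O=C(Nc1ccc(Cl)cc1Cl)c1ccc2cccnc2c1O` gives 430 nM. These two values lie within the usual scatter of repeated measurements, so compound 2 stands level with compound 1 and neither can be ranked ahead of the other.

Compound 3 `N#Cc1ccc(NC(=O)c2ccc3cccnc3c2O)c(Cl)c1` is still unmeasured. It differs from compound 2 in one place: cyano in place of chloro on an aromatic carbon. This is cyano in place of chloro on an aromatic carbon, at a position meta to a chloro group and para to a large group.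

Among the compounds with values here, no measured pair shows this swap on its own, so its size has to be judged indirectly. A cyano group is already present in compound 1, which gives 420 nM. In this assay no step beyond the scatter is therefore expected, and no clear direction either. The estimated step of a 1.1-fold lower number from compound 2 to compound 3 (0.03 log units; within the scatter) is expected to stay small. For compound 3 the expected value is 400 nM, with an estimated range from 170 nM to 950 nM.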

Compound 3, half-maximal inhibitory concentration: 550 nM
Estimate against measurement, compound 3: 1.4-fold (0.14 log units) below; the range from low to high includes it.
By their numbers in this assay, from the lowest: compounds 1, 2 and 3 (each within the scatter of the next).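

In this assay, within the data shown here, putting a cyano group in place of the chloro group on this aromatic carbon, para to a large group, gives a 1.3-fold higher number from compound 2 to compound 3 (0.11 log units; within the scatter) and provides the first direct comparison of these two groups at this position. The read-out does not separate them, even though the entering group has one more heavy atom and one hydrogen-bond acceptor that the chloro group lacks. With the cyano group kept, the other single change, chloro in place of fluoro on an aromatic carbon, gives a 1.3-fold higher number from compound 1 to compound 3 (0.12 log units; within the scatter), so neither one-place change among these three compounds moves the value beyond the usual variation between repeat measurements, and no separate measurement is available to explain these results.

On these data alone, it remains open whether an amine, a methoxy group or a carboxylic acid on this aromatic carbon would give a value in the same range as the chloro and cyano groups. These three compounds also cannot show whether either swap would give a similar result on a different core or in a different kind of test.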